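The source may report more compounds than this note shows. Statements on the series, on what has been measured and on what is new or still open speak of the compounds shown alone.

In a functional assay on MCF7 cells (Homo sapiens) for antiproliferative activity, read by MTT assay, with a stated time of 48 h (on this read-out higher numbers stand for weaker inhibition and lower numbers for stronger inhibition), compound 1 (`CC(=O)O[C@]1(C)/C=C/C(=O)/C(CO)=C\C[C@](C)(CCC=C(C)C)/C=C/[C@H]1OC(=O)C=C(C)C`) gives 2320 nM, compound 2 (`CCN(CC)C/C1=C/C[C@](C)(CCC=C(C)C)/C=C/[C@@H](OC(=O)C=C(C)C)[C@](C)(O)/C=C/C1=O`) gives 130 nM and compound 3 (`CC(C)=CCC[C@]1(C)/C=C/[C@@H](OC(=O)C=C(C)C)[C@](C)(O)/C=C/C(=O)/C(CN2CCCC2)=C\C1`) gives 220 nM. Compound 3 thus sits within the scatter of compound 2 and well under compound 1. Compound 4 (`CSC(=S)OC/C1=C/C[C@](C)(CCC=C(C)C)/C=C/[C@@H](OC(=O)C=C(C)C)[C@](C)(O)/C=C/C1=O`) differs from compound 3 by a group of 5 heavy atoms (2 carbon, 1 oxygen, 2 sulfur; no ring) in place of a group of 5 heavy atoms (4 carbon, 1 nitrogen; one five-membered non-aromatic ring with 1 hetero atom), on a saturated chain carbon bound to a double-bonded ring carbon. For the measured compounds named here, the only measured step at this place is a 1.7-fold higher number from compound 2 to compound 3 (0.23 log units; within the scatter), and it exchanges one nitrogen group for another, so it does not cover the new group. Compound 1, with no nitrogen group there, gives 2320 nM, but it also differs elsewhere, so it offers only a weak hint of a higher number. A modest step is therefore expected, estimated as a 2.3-fold higher number from compound 3 to compound 4 (0.36 log units; beyond the scatter). For compound 4 the estimated value is 500 nM, with an expected range of 150 nM to 1700 nM.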

Compound 4, half-maximal inhibitory concentration: 900 nM
Estimate against measurement, compound 4: 1.8-fold (0.26 log units) below; the range from low to high includes it.
By their numbers in this assay, from the lowest: compounds 2 and 3 (each within the scatter of the next); then compound 4; then compound 1.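

In this assay there is a 4.1-fold higher number from compound 3 to compound 4 (0.61 log units; beyond the scatter) and a 6.9-fold higher number from compound 2 to compound 4 (0.84 log units; beyond the scatter) when the group with 2 sulfur atoms replaces pyrrolidin-1-yl and diethylamino on a saturated chain carbon bound to a double-bonded ring carbon. The exchange between the two nitrogen groups stayed within the scatter, whereas these steps show that a group without nitrogen at this place can shift the number beyond it. No available evidence accounts for these steps. Going by these compounds, it remains open whether other nitrogen groups, such as morpholine or piperidine, would stay with compound 2 and compound 3. A sulfur-free group without nitrogen, such as a methyl ether, would be needed to separate the loss of nitrogen from the sulfur atoms.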